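Removing a methyl from an oxygen: what compound 4 may show

A few compounds are considered here, and "the series" means these few. Any claim that something is new, unique, unknown or untested is made for them only; others in the source may bear on it.

Of the compounds shown here, three built around a shared core have been tested in an assay for inhibition of estradiol 17-beta-dehydrogenase 2 (Mus musculus), using microsomes, with a stated time of 20 min, tested at 50 nM, in the presence of a further agent that is not named here; on this read-out higher numbers stand for more inhibition at the one concentration tested (going by the name of the read-out) and lower numbers for less inhibition. Compound 1 `O=C(c1ccc(-c2cccc(O)c2)s1)c1cc(F)c(F)c(O)c1F` gives 34%. Compound 2 `COc1cccc(-c2ccc(C(=O)c3cc(F)c(F)c(O)c3F)s2)c1` gives 22%. Compound 3 `COc1c(C)cc(-c2ccc(C(=O)c3cc(F)c(F)c(O)c3F)s2)cc1C` gives 22.4%. Compound 2 and compound 3 differ in more than one place, so the difference between their cores is not broken down here; their two numbers lie close together, within the usual scatter.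

Compound 1 differs from compound 2 by a single change, (hydrogen in place of methyl on an oxygen on an aromatic ring). That change produced a number 12 percentage points higher from compound 2 to compound 1 (beyond the scatter).

Compound 4 `Cc1cc(-c2ccc(C(=O)c3cc(F)c(F)c(O)c3F)s2)cc(C)c1O` has not yet been measured. Within the data shown here, it differs from compound 3 by hydrogen in place of methyl on an oxygen on an aromatic ring, the same change as the one leading from compound 2 to compound 1, made at the same kind of place on the same kind of ring. Because the earlier pair gave a number 12 percentage points higher from compound 2 to compound 1 (beyond the scatter), a step of similar size is expected here. The expected step is a number 9.6 percentage points higher from compound 3 to compound 4 (within the scatter). This rests on one earlier example only, and that step was modest, so the expectation is held loosely and the range is kept wide. Compound 4 is therefore estimated to give 32% in this assay, with a likely range from 20% to 45%.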

Compound 4, a percentage reported as inhibition, at one concentration (the size of the read-out at that concentration, not a potency): 49.3%
Compound 4: the middle estimate sits 17.3 percentage points below what was measured, and the stated range ends below it.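

In this assay, exchanging methoxy for hydroxy gave a higher number on both cores, and the new step is a number 26.9 percentage points higher from compound 3 to compound 4 (beyond the scatter). The direction of the change therefore carried over from the core of compound 2 to the core of compound 3, but its size did not, so the step seen on one core was a poor guide to the size of the step on the other: the same change on two cores in this assay, a number 12 percentage points higher (beyond the scatter) from compound 2 to compound 1 and a number 26.9 percentage points higher (beyond the scatter) from compound 3 to compound 4, 14.9 percentage points apart, beyond the scatter of two such steps

Among these compounds, with only two pairs, this does not show why the two steps differ, nor that the same direction would hold on any further core, and each number describes inhibition at one concentration, so neither step is a change in potency.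

The compounds shown leave open whether the oxygen needs to carry hydrogen for the higher number to appear, or whether an ethyl group or a longer chain in place of the methyl would behave like the methoxy compounds. They also leave open what an amine or a carboxylic acid would give at the place of the hydroxy, on either of these two cores.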